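Cyclohexyl for Isopropyl on the Amine-Bearing Side Chain

The compounds below may be only part of what the source reports. "The series", "measured", "known", "first", "only" and "open" are said of these compounds alone.

Compound 2 `COc1cccc(-c2c(C)n(Cc3c(F)cccc3F)c(=O)n(C[C@H](N)C(C)C)c2=O)c1F` gives 51 nM in an assay on HEK293 cells for binding affinity to Gonadotropin-releasing hormone receptor (Homo sapiens), read by radioligand binding (on this read-out lower numbers stand for stronger inhibition and higher numbers for weaker inhibition), and stands level with compound 1 `COc1cccc(-c2c(C)n(Cc3c(F)cccc3F)c(=O)n(C[C@H](C)NCc3ccccc3)c2=O)c1F`, which gives 51 nM in this assay. For the measured compounds named here, the only measured step, no change at the digits printed from compound 1 to compound 2 (within the scatter), alters a different part of the molecule and so bears only loosely on the present change. Compound 3 `COc1cccc(-c2c(C)n(Cc3c(F)cccc3F)c(=O)n(C[C@H](N)C3CCCCC3)c2=O)c1F` differs from compound 2 by cyclohexyl in place of isopropyl on a saturated chain carbon bound to an amine nitrogen and a saturated chain carbon. Going by the values given here, with no measured step covering this exchange, the expected step is a 1.3-fold lower number from compound 2 to compound 3 (0.11 log units; within the scatter), not beyond the scatter. Compound 3 is therefore estimated at 40 nM, with a range from 15 nM to 130 nM.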

Compound 3, inhibition constant: 6.5 nM
The estimate for compound 3 lay 6.2-fold (0.79 log units) above the measured number, and the stated range ends above it.
By their numbers in this assay, from the lowest: compound 3; then compounds 1 and 2 (each within the scatter of the next).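

The side chain had shown no difference between compound 1 and compound 2, but the carbon bearing the amine does respond to its substituent: cyclohexyl in place of isopropyl gives a clear gain (a 7.8-fold lower number from compound 2 to compound 3 (0.89 log units; beyond the scatter)). The amino(cyclohexyl)methyl group also improves on 1-(benzylamino)ethyl (a 7.8-fold lower number from compound 1 to compound 3 (0.89 log units; beyond the scatter)). Nothing available here accounts for this gain. From the compounds shown here alone, how phenyl, cyclopentyl or a longer alkyl chain would fare on this carbon stays open, as does whether a benzyl group on the amine nitrogen of compound 3 would change its number.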